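From a Dichlorophenoxy Group to a Methoxyphenylsulfanyl Group

This account rests on a few compounds, and the source may have more. Where it says the series, first, only, none or still open, it means among the compounds named here.

Compound 1 `Nc1cc(N)c2nc(-c3ccccc3)c(Oc3ccc(Cl)c(Cl)c3)nc2c1` was tested in a functional assay on HOP-62 cells (Homo sapiens) for inhibition, read by sulforhodamine B assay, with a stated time of 48 h (a lower number here means a stronger inhibitor of growth, a higher number a weaker inhibitor of growth), where compound 1 gives 38000 nM, the only plain number among the results shown. Compound 2 `CCOC(=O)[C@H](CCC(=O)O)NC(=O)c1ccc(CNc2nc3cc(N)cc(N)c3nc2-c2ccccc2)cc1` is reported in this assay only as a limit, < 100000 nM, and so adds no number for comparison. Compound 3 `COc1ccc(Sc2nc3cc(N)cc(N)c3nc2-c2ccccc2)cc1` differs from compound 1 by (4-methoxyphenyl)sulfanyl in place of 3,4-dichlorophenoxy on an aromatic carbon. Going by the values given here, no measured pair isolates such a change, so the step is expected to stay within the usual scatter, with no clear direction. For compound 3 the expected step is a 1.1-fold higher number from compound 1 to compound 3 (0.02 log units; within the scatter). Compound 3 is therefore estimated at 40000 nM, within a range from 12000 nM to 120000 nM.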

Compound 3, concentration for total growth inhibition: < 100000 nM
Compound 3: no number, only a limit; the forecaster's own chance of this, stated with the estimate: 25%; the middle value does not contradict the limit.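

Compound 3 is reported in this assay only as a limit, < 100000 nM, so no step from compound 1 to compound 3 can be read: the limit of < 100000 nM in this assay, at which 2 of the 3 values shown sit.

The compounds shown leave open whether (4-methoxyphenyl)sulfanyl in place of 3,4-dichlorophenoxy changes growth inhibition, and in which direction.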